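Fluorophenyl in Place of Pyridyl on a Weak Diamide

The source may hold more compounds than are shown below. What is called first, only, known or untested is meant among the compounds shown, and "the series" means these compounds.

Compound 1, `O=C(Cc1ccccn1)N[C@H]1CCC[C@H](NC(=O)c2cccc(Cl)c2)C1`, gives > 10000 nM in a functional assay on HEK293 cells for antagonist activity at metabotropic glutamate receptor 5 (Homo sapiens), read by FLIPR and calcium flux (a lower number here means a stronger inhibitor, a higher number a weaker inhibitor), which is a limit of the assay and not a number. Compound 2, `O=C(N[C@H]1CCC[C@H](NC(=O)c2ccccn2)C1)c1cccc(Cl)c1`, gives > 10000 nM in this assay, again only a limit of the assay. Compound 3, `O=C(N[C@@H]1CCC[C@H](NC(=O)c2ccccn2)C1)c1cccc(Cl)c1`, gives 1510 nM in this assay.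

Compound 2 therefore stands at the limit of this assay, with no number of its own, and it shares that position with compound 1 (the limit of > 10000 nM in this assay, at which 2 of the 3 values shown sit); only compound 3 gives a readable value. Compound 4, `O=C(N[C@H]1CCC[C@H](NC(=O)c2cccc(Cl)c2)C1)c1ccc(F)cc1`, differs from compound 2 by 4-fluorophenyl in place of pyridin-2-yl on a carbonyl carbon.

For the measured compounds named here, two measured steps touch compound 2. The step that the two limits leave unreadable from compound 1 to compound 2 changes the other carbonyl substituent and cannot be read between two limits. The step of an at least 6.6-fold lower number from compound 2 to compound 3 (0.82 log units; beyond the scatter) is large, but it rests on (the fact that compounds 2 and 3 differ only in the configuration as drawn), a change of configuration alone, and says nothing about the aryl group exchanged here. Going by the values given here, no measured pair swaps the ring on this carbonyl carbon, so the expectation for compound 4 leans on the limit of compound 2 and on the wide spread of outcomes that a fresh ring could bring.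

Compound 4 is expected to stay weak, near the limit, with an estimated 12000 nM in this assay, lying between 2500 nM and 50000 nM. This estimate means a step that the limit leaves unreadable from compound 2 to compound 4, not readable against a limit.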

Compound 4, half-maximal inhibitory concentration: 194 nM
Beside the measured number, compound 4's estimate is 62-fold (1.79 log units) above it; measured number below the stated range.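

For the compounds shown here, until this result, the only readable value in this assay had come with a change of configuration alone: the fact that compounds 2 and 3 differ only in the configuration as drawn. Compound 4 shows that exchanging the group on this carbonyl carbon can also bring a readable value, with 4-fluorophenyl in place of pyridin-2-yl giving an at least 51-fold lower number from compound 2 to compound 4 (1.71 log units; beyond the scatter), and 4-fluorophenyl in place of (pyridin-2-yl)methyl giving an at least 51-fold lower number from compound 1 to compound 4 (1.71 log units; beyond the scatter). Going by these compounds alone, both steps start from a limit of the assay and not from a number, so each gives only a minimum size, and the position proves far more responsive than the earlier compounds could show.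

The compounds shown leave open which part of the exchange matters, the loss of the ring nitrogen or the arrival of the fluorine, and an unsubstituted phenyl group on this carbonyl carbon would separate the two. They also leave open whether a 4-chlorophenyl or 4-methoxyphenyl group there would read like 4-fluorophenyl, and how 4-fluorophenyl would read with the ring configuration of compound 3.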